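From a Difluorobenzyl Sulfide to an Ethyl Sulfone

A few compounds are considered here, and "the series" means these few. Any claim that something is new, unique, unknown or untested is made for them only; others in the source may bear on it.

Compound 3 `Cc1cc(OCc2nnc(SCc3ccc(F)c(F)c3)o2)cc2oc(=O)cc(C)c12` shares its core with compound 1 `CCCSc1nnc(COc2cc(C)c3c(C)cc(=O)oc3c2)o1` and compound 2 `Cc1cc(OCc2nnc(SCc3cccc(F)c3)o2)cc2oc(=O)cc(C)c12`. In a functional assay on MDA-MB-231 cells (Homo sapiens) for antiproliferative activity, read by MTT assay, with a stated time of 24 h (a lower number here means a stronger inhibitor, a higher number a weaker inhibitor), compound 3 reaches only a limit of the assay, > 100000 nM. Compound 1 likewise gives only a limit, > 100000 nM. Compound 2 too gives only a limit, > 100000 nM. Among the measured compounds shown here, every value measured so far is therefore (the limit of > 100000 nM in this assay, at which 3 of the 3 values shown sit). The steps a step that the two limits leave unreadable from compound 1 to compound 2, a step that the two limits leave unreadable from compound 1 to compound 3 and a step that the two limits leave unreadable from compound 2 to compound 3 cannot be sized, so they give no direction. Compound 4 `CCS(=O)(=O)c1nnc(COc2cc(C)c3c(C)cc(=O)oc3c2)o1` differs from compound 3 by ethylsulfonyl in place of (3,4-difluorobenzyl)sulfanyl on an aromatic carbon. With no readable step to lean on, compound 4 is expected to give about 150000 nM, somewhere between 30000 nM and 1000000 nM. That amounts to an expected step that the limit leaves unreadable from compound 3 to compound 4, most likely again reported only as a limit.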

Compound 4, half-maximal inhibitory concentration: > 100000 nM
Compound 4: a limit, no number; the forecaster's own chance of this, stated with the estimate: 80%; the middle value does not contradict the limit.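

Compound 4, like compound 1, compound 2 and compound 3, gives only a limit, so no step among them can be read: the limit of > 100000 nM in this assay, at which 4 of the 4 values shown sit.

The compounds shown leave open whether propylsulfanyl, (3-fluorobenzyl)sulfanyl, (3,4-difluorobenzyl)sulfanyl and ethylsulfonyl differ at all in this assay.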